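The source may hold more compounds than are shown below. What is called first, only, known or untested is meant among the compounds shown, and "the series" means these compounds.

Measured so far:
Compound 1 `CCC1=C(O)c2c(oc(-c3ccc(CBr)cc3)cc2=O)C(CC)(CC)C1=O`: > 46.5 uM
Compound 2 `CCC1=C(O)c2c(oc(-c3ccc(OC)c(C)c3C)cc2=O)C(CC)(CC)C1=O`: 5.43 uM

These results come from a functional assay on KB cells (Homo sapiens) for antiproliferative activity, read by sulforhodamine B assay, with a stated time of 3 days; a higher number here means that more compound is needed for the effect, a lower number that less compound is needed. The entry for compound 1 is a limit of the assay, not a number. Among the compounds with values here, that leaves compound 2 with the only actual number, 5.43 uM.

Compound 3 `CCC1=C(O)c2c(oc(-c3cccc(C)c3C)cc2=O)C(CC)(CC)C1=O` has hydrogen in place of methoxy on an aromatic carbon, para to a large group: hydrogen in place of methoxy on an aromatic carbon. Within the data shown here, no measured pair shows what this swap does, so the expectation is uncertain. The expected change is a 1.5-fold higher number from compound 2 to compound 3 (0.17 log units; within the scatter), a modest step towards a higher number. For compound 3 the estimated value is 8 uM, within an expected range of 3 uM to 25 uM.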

Compound 3, concentration for half-maximal effect: 3.1 uM
Compound 3: the middle estimate sits 2.6-fold (0.41 log units) above what was measured; low and high end bracket the measured number.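

In this assay, hydrogen in place of methoxy, at the position para to a large group, gives a 1.8-fold lower number from compound 2 to compound 3 (0.24 log units; within the scatter), so compound 3 stays active without the methoxy. 2,3-dimethylphenyl in place of 4-(bromomethyl)phenyl gives an at least 15-fold lower number from compound 1 to compound 3 (1.17 log units; beyond the scatter). For compound 1, this step starts from a limit of the assay, not a number: the limit of > 46.5 uM in this assay, at which 1 of the 3 values shown sits.

As far as these compounds go, whether a hydroxyl, a fluorine or an amine at this position would shift the number remains open. So does the contribution of each of the two methyl groups.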